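From an ester to a sulfone on the shared core

This account rests on a few compounds, and the source may have more. Where it says the series, first, only, none or still open, it means among the compounds named here.

Compound 1 `CCCCC(=O)Oc1cc(/C=C/C(=O)c2ccc(OC)c3c2OC(C)(C)C=C3)ccc1OC` gives 100 nM
Compound 2 `COc1ccc(/C=C/C(=O)c2ccc(OC)c3c2OC(C)(C)C=C3)cc1OC(=O)C(C)C` gives 250 nM
Compound 3 `C=CC(=O)Oc1cc(/C=C/C(=O)c2ccc(OC)c3c2OC(C)(C)C=C3)ccc1OC` gives 160 nM

All three numbers come from a functional assay on HepG2 cells (Homo sapiens) for cytotoxicity, read by MTT assay (on this read-out lower numbers stand for stronger inhibition and higher numbers for weaker inhibition), and all three compounds carry an ester on the shared core. Compound 3 cannot be separated from the other two on these numbers: a 1.6-fold higher number from compound 1 to compound 3 (0.20 log units; within the scatter) and a 1.6-fold lower number from compound 2 to compound 3 (0.19 log units; within the scatter) leave it within reach of both. Only a 2.5-fold higher number from compound 1 to compound 2 (0.40 log units; beyond the scatter) goes beyond the scatter, and it is modest.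

Compound 4 `COc1ccc(/C=C/C(=O)c2ccc(OC)c3c2OC(C)(C)C=C3)cc1CS(C)(=O)=O` departs from compound 3 by a larger change (methylsulfonyl)methyl in place of (vinylcarbonyl)oxy on an aromatic carbon in which (methylsulfonyl)methyl stands in place of (vinylcarbonyl)oxy on an aromatic carbon. The measured steps bear on this only loosely. For the measured compounds named here, each alters the group on a carbonyl carbon, and none replaces the ester itself, so no measured compound shows what losing it does. Going by the values given here, with a 2.5-fold higher number from compound 1 to compound 2 (0.40 log units; beyond the scatter) as the only guide beyond the scatter, a step of similar size towards a higher number is expected in this assay with wide margins. The estimated step is a 2.5-fold higher number from compound 3 to compound 4 (0.40 log units; beyond the scatter) and it remains an expectation. Compound 4 is estimated at 400 nM within an expected range of 100 nM to 1600 nM on this read-out.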

Compound 4, half-maximal inhibitory concentration: 9180 nM
Compound 4: the middle estimate sits 23-fold (1.36 log units) below what was measured, outside the stated range (above it).
By their numbers in this assay, from the lowest: compounds 1, 3 and 2 (each within the scatter of the next, the first and the last beyond it); then compound 4.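

In this assay, the aromatic carbon ortho to a methoxy group proves far less tolerant of losing the ester than the changes on its carbonyl carbon had suggested: (methylsulfonyl)methyl in place of (vinylcarbonyl)oxy gives a large step (a 57-fold higher number from compound 3 to compound 4 (1.76 log units; beyond the scatter)), and the same group gives large steps in place of (isopropylcarbonyl)oxy (a 37-fold higher number from compound 2 to compound 4 (1.56 log units; beyond the scatter)) and (butylcarbonyl)oxy (a 92-fold higher number from compound 1 to compound 4 (1.96 log units; beyond the scatter)). For the compounds shown here, all three steps exceed the only step beyond the scatter among the esters, so replacing the whole group matters far more here than altering its end, even though the leaving and entering groups each have 5 heavy atoms, 2 hydrogen-bond acceptors, no hydrogen-bond donors and no ring. Nothing available explains why this replacement has so large an effect.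

The compounds shown leave open whether the large step follows from the loss of the ester or from the arrival of the (methylsulfonyl)methyl group. A hydroxyl, an amide or a methylsulfonyl group bonded directly to this aromatic carbon would help to separate those two readings.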